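A few compounds are considered here, and "the series" means these few. Any claim that something is new, unique, unknown or untested is made for them only; others in the source may bear on it.

Measured compounds:
compound 1 `O=C(CSc1nnc(-c2ccncc2)o1)N/N=C/c1ccc([N+](=O)[O-])cc1`, in a functional assay on MCF7 cells (Homo sapiens) for cytotoxicity, read by MTT assay, with a stated time of 48 h (a lower number here means a stronger inhibitor, a higher number a weaker inhibitor), compound 1 gives 31800 nM
compound 2 `O=C(CSc1nnc(-c2ccncc2)o1)N/N=C/c1ccccc1O`, in this assay compound 2 gives 4750 nM
compound 3 `O=C(CSc1nnc(-c2ccncc2)o1)N/N=C/c1cc(Cl)ccc1O`, in this assay compound 3 gives 5830 nM

All three share the same core and differ only in the aromatic ring attached to the carbon that is double-bonded to nitrogen. Among the three numbers, compound 3 holds the second highest. Its nearest neighbour is compound 2, and the two are within the scatter of each other, as the step of a 1.2-fold higher number from compound 2 to compound 3 (0.09 log units; within the scatter) shows. Its furthest neighbour is compound 1, which lies well beyond the scatter, as seen in a 5.5-fold lower number from compound 1 to compound 3 (0.74 log units; beyond the scatter).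

Compound 4 `O=C(CSc1nnc(-c2ccncc2)o1)N/N=C/c1cc(Br)cc(Br)c1O` is not yet measured. Its change from compound 3 is 3,5-dibromo-2-hydroxyphenyl in place of 5-chloro-2-hydroxyphenyl on a carbon with a double bond to nitrogen. Among the measured compounds shown here, the only measured step that speaks to substituting a halogen on this hydroxyphenyl ring is a 1.2-fold higher number from compound 2 to compound 3 (0.09 log units; within the scatter), which stayed within the scatter. Moving from one halogen to two, and from chloro to bromo, has no measured precedent here, so a step of no more than modest size is expected in this assay, with no clear direction. Compound 4 is therefore estimated at 5000 nM, within a range from 1800 nM to 14000 nM, which corresponds to an expected step of a 1.2-fold lower number from compound 3 to compound 4 (0.07 log units; within the scatter).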

Compound 4, half-maximal inhibitory concentration: 9010 nM
Compound 4: the middle estimate sits 1.8-fold (0.26 log units) below what was measured, within the range that was stated.
By their numbers in this assay, from the lowest: compounds 2, 3 and 4 (each within the scatter of the next); then compound 1.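

In this assay, the 3,5-dibromo-2-hydroxyphenyl group reads much like the other hydroxyphenyl groups at this carbon, with a 1.5-fold higher number from compound 3 to compound 4 (0.19 log units; within the scatter) and a 1.9-fold higher number from compound 2 to compound 4 (0.28 log units; within the scatter), so the position accepts this larger halogen pattern without a step beyond the scatter. The gap to the 4-nitrophenyl group persists, with a 3.5-fold lower number from compound 1 to compound 4 (0.55 log units; beyond the scatter), so all three hydroxyphenyl compounds now stand apart from compound 1. No measurement here explains either observation.

Compound 1 differs from the others both in carrying a nitro group and in lacking the hydroxy group, so these two changes cannot be separated. From the compounds shown here alone, how an amine or a methoxy group on this ring would read also remains open.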